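Adding a sulfamoyl group to a quinone-bearing pyrazole

The source may hold more compounds than are shown below. What is called first, only, known or untested is meant among the compounds shown, and "the series" means these compounds.

Measured compounds:
- Compound 1 `NS(=O)(=O)c1ccc(-n2nc(-c3ccc(Cl)cc3)cc2-c2cc(O)ccc2O)cc1`: 14700 nM
- Compound 2 `O=C1C=CC(=O)C(c2cc(-c3ccc(Cl)cc3)nn2-c2ccccc2)=C1`: 67300 nM

In a functional assay on cells (Cancer cell lines, Homo sapiens) for cytotoxicity, read by sulforhodamine B assay, with a stated time of 48 h (on this read-out lower numbers stand for stronger inhibition of growth and higher numbers for weaker inhibition of growth), compound 2 gives 67300 nM, the higher of the two numbers; compound 1 gives 14700 nM, a clearly lower number. The two differ in two places, so neither change alone can be read from them. Compound 3 `NS(=O)(=O)c1ccc(-n2nc(-c3ccc(Cl)cc3)cc2C2=CC(=O)C=CC2=O)cc1` keeps the quinone of compound 2 and carries sulfamoyl in place of hydrogen on an aromatic carbon. With no single-change comparison available, a modest downward step is expected, a 1.9-fold lower number from compound 2 to compound 3 (0.28 log units; within the scatter), of a size that may not exceed the scatter. Compound 3 is estimated at 35000 nM, within 12000 nM to 100000 nM.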

Compound 3, concentration for 50% growth inhibition: 26500 nM
For compound 3 the middle estimate is 1.3-fold (0.12 log units) above the measured one; the range from low to high includes it.
By their numbers in this assay, from the lowest: compounds 1 and 3 (each within the scatter of the next); then compound 2.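

In this assay, sulfamoyl in place of hydrogen on the aromatic carbon gives a 2.5-fold lower number from compound 2 to compound 3 (0.40 log units; beyond the scatter), so with the quinone kept, this single change has a small but readable effect. With sulfamoyl kept, replacing the aromatic six-membered ring with the quinone gives a 1.8-fold higher number from compound 1 to compound 3 (0.26 log units; within the scatter), and this exchange shows no clear difference. Nothing available explains either result. As far as these compounds go, it remains open whether an amine or a carboxylic acid on the same aromatic carbon would match sulfamoyl.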